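Benzylidene series: sulfur substituent changed, growth inhibition tracked

This account rests on a few compounds, and the source may have more. Where it says the series, first, only, none or still open, it means among the compounds named here.

Compound 1 `O=C(/C(=C\c1c(O)cc(O)cc1O)S(=O)(=O)c1ccccc1Br)c1ccc(Cl)cc1` and compound 2 `O=C(/C(=C\c1c(O)cc(O)cc1O)Sc1ccc(Br)cc1)c1ccc(Cl)cc1` share the same core. In a functional assay on DU-145 cells (Homo sapiens) for inhibition, read by trypan blue exclusion, with a stated time of 96 h (a lower number here means a stronger inhibitor of growth, a higher number a weaker inhibitor of growth), compound 1 gives 50000 nM, and compound 2 gives 50000 nM; the step of no change at the digits printed from compound 1 to compound 2 (within the scatter) puts compound 2 level with compound 1. Compound 3 `O=C(/C(=C\c1c(O)cc(O)cc1O)SCc1ccc(Cl)c(Cl)c1)c1ccc(Cl)cc1` differs from compound 2 by 3,4-dichlorobenzyl in place of 4-bromophenyl on a sulfur. Among the measured compounds shown here, no measured step covers this change; the only step known, from compound 1 to compound 2, altered the sulfur substituent without moving this assay. Compound 3 is therefore expected at 50000 nM, within 15000 nM to 50000 nM, a step of no change at the digits printed from compound 2 to compound 3 (within the scatter) estimated to stay within the scatter.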

Compound 3, concentration for 50% growth inhibition: 25000 nM
Compound 3: middle estimate off by 2.0-fold (0.30 log units), on the high side; measured number inside the range.
By their numbers in this assay, from the lowest: compounds 3, 1 and 2 (each within the scatter of the next).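

In this assay, moving to the (3,4-dichlorobenzyl)sulfanyl group gives a 2.0-fold lower number from compound 2 to compound 3 (0.30 log units; within the scatter) and a 2.0-fold lower number from compound 1 to compound 3 (0.30 log units; within the scatter). Among the compounds shown here, on this sulfur, a benzyl group therefore does not separate from the two bromophenyl groups, and the first compound with a benzyl group on sulfur stays within the scatter of both. No measured evidence bears on this result. Still open, going by these compounds, is whether an amine or a carboxylic acid on the sulfur substituent, or a longer chain between sulfur and the ring, would move growth inhibition beyond the scatter.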